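From compound 2 to compound 3: a larger group on the carbonyl

The source may hold more compounds than are shown below. What is called first, only, known or untested is meant among the compounds shown, and "the series" means these compounds.

compound 1 `CC1=C(CC(=O)N(C)CCN(C)C)c2cc(F)ccc2/C1=C\c1nc2ccccc2s1` reads "not active" (no number reported) in this series
compound 2 `CC1=C(CC(=O)NCCN2CCCC2)c2cc(F)ccc2/C1=C\c1nc2ccccc2s1` reads 47000 nM in this series

Among the measured compounds shown here, in a functional assay on Raji cells (Homo sapiens) for inhibition, read by CellTiter-Glo, with a stated time of 72 h (a lower number here means that less compound is needed, a higher number that more compound is needed for the effect), compound 2 holds the only number so far, and compound 1 gave none. Compound 3 `CC1=C(CC(=O)N2CCN(CCCN(C)C)CC2)c2cc(F)ccc2/C1=C\c1nc2ccccc2s1` carries 4-(3-(dimethylamino)propyl)piperazin-1-yl in place of (2-(pyrrolidin-1-yl)ethyl)amino on a carbonyl carbon. For the measured compounds named here, no measured step is available as a guide, so no change beyond the scatter is expected. The estimated change is (a 1.6-fold lower number from compound 2 to compound 3 (0.19 log units; within the scatter)) and could go either way. For compound 3 the expected value in this assay is about 30000 nM within an estimated range from 10000 nM to 90000 nM if a number is reported at all.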

Compound 3, half-maximal effective concentration: "not active" (no number reported)
No number was reported for compound 3; there is nothing to compare the estimate with.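

Compound 3 reads "not active" without a number, so no step from compound 2 to compound 3 can be read, and nothing shown bears on why. The compounds shown leave open how the group on the carbonyl carbon relates to activity in this assay.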